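The compounds below may be only part of what the source reports. "The series", "measured", "known", "first", "only" and "open" are said of these compounds alone.

Measured compounds:
- compound 1, `COc1cc(NC(C)CCCNC(=O)NCCCO)c2ncccc2c1`: "not determined" (no result reported) in an ADME assay on L6 cells (Rattus norvegicus) for cytotoxicity, read by resazurin assay, with a stated time of 70 h; a higher number here means a weaker inhibitor, a lower number a stronger inhibitor
- compound 2, `COc1cc(NC(C)CCCNC(=O)NNC(=O)/C=C/c2ccccc2)c2ncccc2c1`: 13900 nM

Both compounds share the same core and differ only in the tail that hangs from the urea. For compound 1 the entry in this assay reads "not determined" (no result reported). Going by the values given here, compound 2 gives 13900 nM in this assay, and this is the only number available, so compound 2 stands alone: there is nothing to rank it against, neither stronger nor weaker.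

Compound 3, `COc1cc(NC(C)CCCNC(=O)NNC(=O)/C=C/c2ccccc2F)c2ncccc2c1`, has not yet been measured. It differs from compound 2 in one place: fluoro in place of hydrogen on an aromatic carbon. Among the compounds with values here, no measured pair shows what such a swap does, so the expectation rests on compound 2 alone. Adding a single fluorine to the six-membered aromatic ring of carbon only is a change of one heavy atom, and the expected step from compound 2 to compound 3 is a 1.0-fold higher number from compound 2 to compound 3 (0.00 log units; within the scatter), that is, none beyond the scatter of the measurement in either direction. Compound 3 is therefore estimated at 14000 nM, with a range from 6000 nM to 32000 nM.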

Compound 3, half-maximal inhibitory concentration: 25100 nM
Compound 3: middle estimate off by 1.8-fold (0.25 log units), on the low side, and the stated range covers the measured number.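

Going by these compounds alone, replacing hydrogen with fluoro on the aromatic carbon ortho to a large group gives the first measured step in this assay, namely a 1.8-fold higher number from compound 2 to compound 3 (0.26 log units; within the scatter), for a change of a single heavy atom. That step lies within the usual scatter of repeated measurements, so compound 2 and compound 3 cannot be told apart here, and this one pair shows that a fluoro group at this position leaves the number with no change that can be read. Nothing measured here offers an explanation of this result.

Within the data shown here, one pair describes only one substituent at one ring position, so it remains open whether a fluoro group on another carbon of this ring, or a larger group such as chloro, methoxy or trifluoromethyl on the same carbon, would produce a step beyond the scatter. Going by these compounds, it is also open whether an amine or a carboxylic acid on this phenyl ring would behave in the same way in this assay.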